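The source may hold more compounds than are shown below. What is called first, only, known or untested is meant among the compounds shown, and "the series" means these compounds.

Compound 1 `ClCc1ccc(Cn2cnc3c(Cl)ncnc32)cc1` carries a chlorinated fused core linked through a methylene to a benzene ring that bears a chloromethyl group. In a functional assay on T47D cells (Homo sapiens) for cytotoxicity, read by sulforhodamine B assay, with a stated time of 48 h (on this read-out lower numbers stand for higher toxicity in this test and higher numbers for lower toxicity in this test), compound 1 gives "not determined" (no result reported). Within the data shown here, compound 1 therefore stands at no number in this read-out, and the only further value shown is a limit rather than a number. That limit belongs to compound 2 `ClCc1cccc(Cn2cnc3c(Cl)nc(Cl)nc32)c1`, a close relative with a second chloro group on the core. In this assay compound 2 reaches only the limit > 100000 nM. This is recorded as the limit of > 100000 nM in this assay, at which 1 of the 2 values shown sits. Compound 3 `Nc1nc(Cl)c2ncn(Cc3ccc(CCl)cc3)c2n1` differs from compound 1 by amino in place of hydrogen on an aromatic carbon. Among the measured compounds shown here, no measured step of this kind is available, so in this assay no shift beyond the usual scatter is expected, and a limit is again the likeliest outcome. Compound 3 is expected to give about 100000 nM, within a range from 30000 nM to 300000 nM.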

Compound 3, concentration lethal to 50% of the cells: > 100000 nM
Compound 3: no number, only a limit; the forecaster's own chance of this, stated with the estimate: 70%; the middle value lies on the limit itself.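

No step can be read between compound 1 and compound 3, as compound 1 has no number in this assay. Compound 3 gives > 100000 nM in this assay, which is a limit and not a number. The compounds shown leave open how amino in place of hydrogen changes toxicity in this test.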